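Taking the methyl off compound 2

The source may report more compounds than this note shows. Statements on the series, on what has been measured and on what is new or still open speak of the compounds shown alone.

Measured in an ADME assay on TERT-RPE1 cells (Homo sapiens) for cytotoxicity, read by MTT assay, with a stated time of 72 h; a lower number here means a stronger inhibitor, a higher number a weaker inhibitor:
Compound 1 `COc1ccc(/C=C2\S/C(=N\c3ccc(F)cc3)N(C)C2=O)cc1`: > 100000 nM
Compound 2 `COc1ccc(/C=C2\S/C(=N\c3ccc(C)cc3)N(C)C2=O)cc1`: > 100000 nM

In this assay compound 2 gives > 100000 nM, which is a limit of the assay and not a number. Compound 1 gives > 100000 nM, which is also a limit. The measurements so far therefore offer only (the limit of > 100000 nM in this assay, at which 2 of the 2 values shown sit).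

Among the measured compounds shown here, the next compound is compound 3 `COc1ccc(/C=C2\S/C(=N\c3ccccc3)N(C)C2=O)cc1`, which has no measurement yet. It differs from compound 2 as follows: hydrogen in place of methyl on an aromatic carbon. This is hydrogen in place of methyl on an aromatic carbon, para to a large group, so that 4-methylphenyl becomes phenyl.

For the measured compounds named here, the one measured step that bears on this change is a step that the two limits leave unreadable from compound 1 to compound 2, which involves the same substituent position. It gives no size to carry over, and it points in no direction.

The expected step is a number no higher from compound 2 to compound 3 (the limit leaves the size open), an estimate that assumes no change beyond the scatter. For compound 3 the estimated value in this assay is 100000 nM, with an expected range from 50000 nM to 200000 nM, and the assay may well report only a limit again.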

Compound 3, half-maximal inhibitory concentration: > 100000 nM
Compound 3: a limit, no number; the forecaster's own chance of this, stated with the estimate: 85%; the middle value sits exactly at the limit.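

In this assay compound 3 gives > 100000 nM as a limit of the assay and not a number. No step can be read among compound 1, compound 2 and compound 3, since all three stop at the same limit: the limit of > 100000 nM in this assay, at which 3 of the 3 values shown sit. The compounds shown leave open whether the fluoro, methyl and hydrogen forms differ at all in this read-out.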